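This account rests on a few compounds, and the source may have more. Where it says the series, first, only, none or still open, it means among the compounds named here.

Compound 1 `COc1cc(-c2ncnn2-c2ccc([N+](=O)[O-])cc2)cc(OC)c1OC` — in a functional assay on HL-60 cells (Homo sapiens) for antiproliferative activity, read by MTT assay, with a stated time of 72 h (on this read-out lower numbers stand for stronger inhibition and higher numbers for weaker inhibition), compound 1 gives > 10000 nM, which is a limit of the assay rather than a number.
Compound 2 `COc1cc(-n2ncnc2-c2ccc(OC(F)(F)F)cc2)cc(OC)c1OC` — in this assay compound 2 gives > 10000 nM, again a limit and not a number.
Compound 3 `COc1cc(-c2ncnn2-c2ccc(Cl)c(Cl)c2)cc(OC)c1OC` — in this assay compound 3 gives > 10000 nM, also a limit.

For compound 2 only a limit is known, and the two other values shown are limits too: all three sit at the limit of > 10000 nM in this assay, at which 3 of the 3 values shown sit. For the measured compounds named here, no pair of measured compounds differs in a single place, so no measured step is available to show how any one change moves the read-out.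

Compound 4 `COc1cc(-n2ncnc2-c2ccc(F)cc2)cc(OC)c1OC` has not yet been measured in this assay. It differs from compound 2 by fluoro in place of trifluoromethoxy on an aromatic carbon. With every measured value resting at the limit, there is no ground for expecting a step beyond the usual scatter; the expected step is a step that the limit leaves unreadable from compound 2 to compound 4, essentially none. Compound 4 is therefore expected to give about 15000 nM in this assay, between 5000 nM and 50000 nM, and most likely to return only a limit once more.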

Compound 4, half-maximal inhibitory concentration: > 10000 nM
Compound 4: a limit, no number; the forecaster's own chance of this, stated with the estimate: 75%; the middle value does not contradict the limit.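

No step can be read from compound 2 to compound 4, since in this assay both give only a limit, not a number: the limit of > 10000 nM in this assay, at which 4 of the 4 values shown sit.

The compounds shown leave open how strong any of them really is, and which change, if any, would bring a readable number.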